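The source may hold more compounds than are shown below. What is called first, only, known or untested is meant among the compounds shown, and "the series" means these compounds.

Working notes on the series: in a functional assay on the whole organism for inhibition, with Rattus norvegicus as the target, read by paw edema, with stated times of 1 h and 3 h (on this read-out higher numbers stand for an effect only at larger amounts of compound and lower numbers for an effect already at smaller amounts), compound 1 (`COC(=O)CO/N=C(\C)c1ccc(Cl)cc1`) gives 24 mg/kg and compound 2 (`COC(=O)CO/N=C(\C)c1ccc(Br)cc1`) gives 14 mg/kg. These two numbers lie within the scatter of each other, so compound 1 has no separate standing from compound 2. Within the data shown here, the only measured step is a 1.7-fold lower number from compound 1 to compound 2 (0.23 log units; within the scatter), bromo in place of chloro on an aromatic carbon.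

Compound 3 (`C/C(=N\OCC(N)=O)c1ccc(Cl)cc1`) keeps the chloro of compound 1 and differs elsewhere: amino in place of methoxy on a carbonyl carbon. In words, this is amino in place of methoxy on a carbonyl carbon, or methoxycarbonyl to carbamoyl. The measured step lies at a different place and bears on this change only indirectly. Among the measured compounds shown here, no measured pair covers this change, so the data support neither a size nor a direction for it. The working expectation in this assay is therefore no step beyond the scatter, held with a wide margin on both sides. The expected step is a 1.3-fold higher number from compound 1 to compound 3 (0.10 log units; within the scatter). In this assay the estimate for compound 3 is 30 mg/kg, with an expected range of 10 mg/kg to 90 mg/kg.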

Compound 3, dose for half-maximal effect: 24 mg/kg
Compound 3: the middle estimate sits 1.3-fold (0.10 log units) above what was measured, and the stated range covers the measured number.
By their numbers in this assay, from the lowest: compounds 2, 1 and 3 (each within the scatter of the next).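

In this assay, the step at this carbonyl carbon, whose other neighbour is a saturated chain carbon, reads no change at the digits printed from compound 1 to compound 3 (within the scatter) for amino in place of methoxy on a carbonyl carbon. Among these compounds, the earlier step covered only bromo in place of chloro on an aromatic carbon, so this is the first reading at this position, and it shows that methoxycarbonyl can give way to carbamoyl, with the chloro kept, without a step beyond the scatter. No measurement offered alongside this pair speaks to why the read-out stays within the scatter on this change.

As far as these compounds go, whether the same holds with bromo in place of chloro on the aromatic carbon remains open, since the carbamoyl group appears here only in compound 3, and this single pair gives no trend for the position. Also open, from the compounds shown here alone, is how the read-out responds when the carbonyl carbon carries other groups, such as a carboxylic acid, an ethyl ester or a dimethylamino amide, or when carbamoylmethyl gives way to a longer chain.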